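The source may report more compounds than this note shows. Statements on the series, on what has been measured and on what is new or still open speak of the compounds shown alone.

Measured in a functional assay on SW-620 cells (Homo sapiens) for inhibition, read by sulforhodamine B assay, with a stated time of 48 h, tested at 10 uM; on this read-out lower numbers stand for less inhibition and higher numbers for more inhibition at the one concentration tested (going by the name of the read-out):
Compound 1 `COc1ccc(-c2cn3ccnc3c(-c3ccc4ncn(C5CCCCC5)c4c3)n2)cc1` gives 77.8%.
Compound 2 `O=Cc1ccc(-c2cn3ccnc3c(-c3ccc4ncn(C5CCCCC5)c4c3)n2)cc1` gives 4.21%.
Compound 3 `CCc1ccc(-c2cn3ccnc3c(-c3ccc4ncn(Cc5ccccc5)c4c3)n2)cc1` gives 18.8%.

Compound 3 stands second highest of the three: compound 2 is nearer and lower by an amount beyond the scatter, while compound 1 is higher by a gap well beyond the scatter.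

Compound 4 `O=Cc1ccc(-c2cn3ccnc3c(-c3ccc4ncn(Cc5ccccc5)c4c3)n2)cc1` differs from compound 3 in one place: formyl in place of ethyl on an aromatic carbon. Within the data shown here, the one measured step that bears on this change is a number 73.6 percentage points lower from compound 1 to compound 2 (beyond the scatter), where the same formyl group entered, there in place of methoxy. That step was large and downward. The account therefore expects a step downward in this assay for compound 4, smaller only because compound 3 already gives 18.8%, a low starting point. Compound 4 is estimated at 5%, with a range from 0% to 20%, an expected step of a number 13.8 percentage points lower from compound 3 to compound 4 (beyond the scatter).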

Compound 4, a percentage reported as inhibition, at one concentration (the size of the read-out at that concentration, not a potency): 4.21%
Beside the measured number, compound 4's estimate is 0.8 percentage points above it, within the range that was stated.
By their numbers in this assay, from the lowest: compounds 2 and 4 (each within the scatter of the next); then compound 3; then compound 1.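

In this assay, formyl on this aromatic carbon, para to a large group, also gives a lower number when it replaces ethyl, with a number 14.6 percentage points lower from compound 3 to compound 4 (beyond the scatter), so the fall is not seen against methoxy alone. With formyl on that carbon, benzyl in place of cyclohexyl on the aromatic nitrogen gives no change at the digits printed from compound 2 to compound 4 (within the scatter). No evidence is available that accounts for either result. The compounds shown leave open whether an amine or a carboxylic acid on this carbon would read closer to formyl or to methoxy, and whether benzyl and cyclohexyl also match when methoxy or ethyl occupies it.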